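Piperidinylmethyl on the side chain of a shared core

A few compounds are considered here, and "the series" means these few. Any claim that something is new, unique, unknown or untested is made for them only; others in the source may bear on it.

Measured compounds:
- compound 1 `CCn1c(N)c(-c2nc3ccccc3[nH]2)c2nc(C#N)c(C#N)nc21`: > 50000 nM in a functional assay on cells (Homo sapiens) for antiproliferative activity, read by MTT assay, with a stated time of 48 h; on this read-out lower numbers stand for stronger inhibition and higher numbers for weaker inhibition
- compound 2 `CCCn1c(N)c(-c2nc3ccccc3[nH]2)c2nc(C#N)c(C#N)nc21`: > 50000 nM
- compound 3 `CCN(CC)CCCn1c(N)c(-c2nc3ccccc3[nH]2)c2nc(C#N)c(C#N)nc21`: 28900 nM

Compound 1 gives only a limit of the assay, not a number. Compound 2 likewise sits at a limit, so that a step that the two limits leave unreadable from compound 1 to compound 2. Among the measured compounds shown here, compound 3 is the only one with a measured number, and the step of an at least 1.7-fold lower number from compound 1 to compound 3 (0.23 log units; that floor lies within the scatter) reaches at least its floor, which still lies within the scatter of this kind of measurement. Both limits are the same one: the limit of > 50000 nM in this assay, at which 2 of the 3 values shown sit.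

Compound 4 `N#Cc1nc2c(-c3nc4ccccc4[nH]3)c(N)n(CCCN3CCCCC3)c2nc1C#N` differs from compound 1 in one place: (piperidin-1-yl)methyl in place of hydrogen on a saturated chain carbon, two bonds along the chain from an aromatic nitrogen. For the measured compounds named here, the step most like it is the one from compound 1 to compound 3, where a (diethylamino)methyl entered at the same place. On that basis compound 4 is expected to come off the limit in much the same way, giving an estimated step of an at least 2.0-fold lower number from compound 1 to compound 4 (0.30 log units; that floor lies within the scatter). Compound 4 is therefore estimated at 25000 nM, within a range from 8000 nM to 50000 nM.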

Compound 4, half-maximal inhibitory concentration: 6230 nM
Compound 4: the middle estimate sits 4.0-fold (0.60 log units) above what was measured; measured number below the stated range.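

In this assay, putting (piperidin-1-yl)methyl on this chain carbon gives a step that clears the scatter, an at least 8.0-fold lower number from compound 1 to compound 4 (0.90 log units; beyond the scatter), and the same holds for an at least 8.0-fold lower number from compound 2 to compound 4 (0.90 log units; beyond the scatter), whereas the floors of the steps to the diethylamino compound stayed within it. What ends the chain therefore matters, not merely that an amine is there: changing diethylamino to piperidin-1-yl gives a 4.6-fold lower number from compound 3 to compound 4 (0.67 log units; beyond the scatter). The two steps from compound 1 and compound 2 are floors rather than sizes, because both compounds sit at a limit: the limit of > 50000 nM in this assay, at which 2 of the 4 values shown sit.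

Going by these compounds, whether a pyrrolidin-1-yl or morpholin-4-yl group at the chain end would give a lower number remains open. So does the effect of a longer chain carrying the same piperidin-1-yl group.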